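The source may hold more compounds than are shown below. What is called first, only, known or untested is meant among the compounds shown, and "the series" means these compounds.

Working notes on the triazole series. In a functional assay on PC-12 cells (Rattus norvegicus) for cytotoxicity, read by MTT assay, with stated times of 2 h and 24 h, tested at 10 uM (on this read-out higher numbers stand for a stronger effect at the one concentration tested and lower numbers for a weaker effect), compound 3 `Oc1cc(C(F)(F)F)ccc1-c1nc(-c2ccccc2O)n(-c2ccccc2Cl)n1` gives 102%, level with compound 1 `Oc1cc(C(F)(F)F)ccc1-c1nc(-c2ccccc2O)n(-c2ccc(C(F)(F)F)cc2)n1`, which gives 102%, and within the scatter of compound 2 `COc1ccc(-n2nc(-c3ccc(C(F)(F)F)cc3O)nc2-c2ccccc2O)cc1`, which gives 98.9%. All three numbers sit close together; the steps of a number 3.1 percentage points lower from compound 1 to compound 2 (within the scatter), no change at the digits printed from compound 1 to compound 3 (within the scatter) and a number 3.1 percentage points higher from compound 2 to compound 3 (within the scatter) are each within the scatter.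

Compound 4 `Oc1cc(C(F)(F)F)ccc1-c1nc(-c2ccccc2O)n(-c2cccc(F)c2)n1` is still unmeasured. Relative to compound 3 the change is 3-fluorophenyl in place of 2-chlorophenyl on an aromatic nitrogen. The measured steps that bear on it are those swapping the group on the aromatic nitrogen, no change at the digits printed from compound 1 to compound 3 (within the scatter) and a number 3.1 percentage points higher from compound 2 to compound 3 (within the scatter), both within the scatter. The expected step is therefore a number 1 percentage points lower from compound 3 to compound 4 (within the scatter), with no movement beyond the scatter. Compound 4 is expected at 101%, within a range of 92% to 110%.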

Compound 4, a percentage reported as activity, at one concentration (the size of the read-out at that concentration, not a potency): 98.3%
Compound 4: middle estimate off by 2.7 percentage points, on the high side; low and high end bracket the measured number.
By their numbers in this assay, from the lowest: compounds 4, 2, 1 and 3 (each within the scatter of the next).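

In this assay the 3-fluorophenyl group on the aromatic nitrogen stays within the scatter of all three earlier groups: a number 3.7 percentage points lower from compound 3 to compound 4 (within the scatter), a number 0.6 percentage points lower from compound 2 to compound 4 (within the scatter) and a number 3.7 percentage points lower from compound 1 to compound 4 (within the scatter). This position has now carried four different substituted phenyl groups with no step beyond the scatter. No measurement at hand explains why these numbers sit so close together.

Still open, going by these compounds, is whether a group other than substituted phenyl on this nitrogen, such as a longer alkyl chain, an amine or a carboxylic acid, would give a step beyond the scatter.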